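The compounds below may be only part of what the source reports. "The series", "measured", "known", "first", "only" and "open" are said of these compounds alone.

Compound 1 `Cc1ccc(O)c(N(CCCN2CCN(C(c3ccccc3)c3ccc(Cl)cc3)CC2)C(C)C)c1` gives 0.44 ug/mL in a functional assay on the whole organism with Rattus norvegicus as the target; a lower number here means a stronger inhibitor, a higher number a weaker inhibitor. Compound 2 `Cc1ccc(O)c(N(CCCN2CCN(C(c3ccc(Cl)cc3)c3ccc(Cl)cc3)CC2)C(C)C)c1` carries chloro in place of hydrogen on an aromatic carbon and gives 2.2 ug/mL in this assay; the step is a 5.0-fold higher number from compound 1 to compound 2 (0.70 log units; beyond the scatter). Compound 3 `Cc1ccc(O)c(NCCCN2CCC(C(O)(c3ccccc3)c3ccccc3)CC2)c1` gives 0.029 ug/mL in this assay, the lowest of the three numbers, and the difference between its core and the core of compound 1 is not broken down here. Compound 4 `Cc1ccc(O)c(NCCCN2CCC(C(O)(c3ccccc3)c3ccc(Cl)cc3)CC2)c1` has not yet been measured; it differs from compound 3 by chloro in place of hydrogen on an aromatic carbon. The place of this change reads the same word for word as for compound 2, so on the second core it is the same kind of change. Compound 4 is expected to give 0.11 ug/mL in this assay, between 0.03 ug/mL and 0.45 ug/mL. Among the measured compounds shown here, that estimate means a 3.8-fold higher number from compound 3 to compound 4 (0.58 log units; beyond the scatter), expected to resemble the earlier step because a 5.0-fold higher number from compound 1 to compound 2 (0.70 log units; beyond the scatter) is the same kind of change; only one earlier instance exists, so the expectation is wide.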

Compound 4, half-maximal inhibitory concentration: 0.041 ug/mL
Beside the measured number, compound 4's estimate is 2.7-fold (0.43 log units) above it; measured number inside the range.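

In this assay, chloro in place of hydrogen on the core of compound 3 gives a 1.4-fold higher number from compound 3 to compound 4 (0.15 log units; within the scatter), a step that cannot be told apart from no change. The same change therefore does not carry over at the same size from one core to the other: the same change on two cores in this assay, a 5.0-fold higher number (0.70 log units; beyond the scatter) from compound 1 to compound 2 and a 1.4-fold higher number (0.15 log units; within the scatter) from compound 3 to compound 4, 3.5-fold (0.55 log units) apart, beyond the scatter of two such steps

With a single pair on each core, this does not show which difference between the cores goes with the gap, and compound 1 already carries one chloro where compound 3 carries none.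

Still open, on these data alone, is whether fluoro, methoxy or trifluoromethyl at the same place would give a step nearer the one on the first core or the one on the second. Among the compounds shown here, also open is whether a second chloro on the other phenyl ring of compound 4 would give a step like the one from compound 1 to compound 2.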